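A few compounds are considered here, and "the series" means these few. Any claim that something is new, unique, unknown or untested is made for them only; others in the source may bear on it.

Measured so far in a functional assay on A549 cells (Homo sapiens) for antiproliferative activity, read by MTT assay, with a stated time of 72 h; a higher number here means a weaker inhibitor, a lower number a stronger inhibitor:
- compound 1 `COc1cc2c(Nc3ccc(C#N)cc3)ncnc2cc1OCCCN(C)Cc1ccccc1`: > 100000 nM (a limit)
- compound 2 `COc1cc2c(Nc3ccc(C#N)cc3)ncnc2cc1OCCCN1CCC(O)CC1`: 29900 nM
- compound 3 `COc1cc2c(Nc3ccc(C#N)cc3)ncnc2cc1OCCCN1CCc2ccccc2C1`: > 100000 nM (a limit)

Compound 3 gives > 100000 nM, which is a limit and not a number. Compound 1 likewise gives only a limit, > 100000 nM. These two sit at the limit of > 100000 nM in this assay, at which 2 of the 3 values shown sit, and compound 2 is the only one of the three with a number.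

Compound 4 `COc1cc2c(Nc3ccc(C#N)cc3)ncnc2cc1OCCCN1CCC(N2CCCCC2)CC1` keeps the shared core and chain of compound 3 and changes only the terminal group: 4-(piperidin-1-yl)piperidin-1-yl in place of 1,2,3,4-tetrahydroisoquinolin-2-yl on a saturated chain carbon, three bonds along the chain from an oxygen on an aromatic ring. The six-membered aromatic ring of carbon only leaves with 1,2,3,4-tetrahydroisoquinolin-2-yl, and the entering group has only six-membered non-aromatic rings.

The nearest measured evidence is an at least 3.3-fold higher number from compound 2 to compound 3 (0.52 log units; beyond the scatter), the reverse of an at least 3.3-fold lower number from compound 1 to compound 2 (0.52 log units; beyond the scatter). Both lie beyond the scatter, and both are bounded by a limit on one side. a step that the two limits leave unreadable from compound 1 to compound 3 adds nothing on size. The analogy with compound 2 is only partial, since 4-(piperidin-1-yl)piperidin-1-yl has no hydrogen-bond donors.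

In this assay, a move to a lower number is therefore expected, of modest size, resting on compound 2 at 29900 nM. The expected change is an at least 3.3-fold lower number from compound 3 to compound 4 (0.52 log units; beyond the scatter). For compound 4 the estimate is 30000 nM, with an expected range from 8000 nM to 100000 nM.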

Compound 4, half-maximal inhibitory concentration: 30700 nM
Compound 4: middle estimate off by 1.0-fold (0.01 log units), on the low side; low and high end bracket the measured number.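

In this assay, the terminal group on the saturated chain carbon, three bonds along the chain from an oxygen on an aromatic ring, now has a second member that returns a number, with an at least 3.2-fold lower number from compound 3 to compound 4 (0.51 log units; beyond the scatter) and an at least 3.2-fold lower number from compound 1 to compound 4 (0.51 log units; beyond the scatter), each step bounded on one side by a limit of the assay. With piperidin-1-yl in place of hydroxy on a saturated ring carbon, the series shows a 1.0-fold higher number from compound 2 to compound 4 (0.01 log units; within the scatter), so a value at this level does not depend on the hydroxy group of compound 2 and persists in a terminal group with no hydrogen-bond donors. Among the four compounds, compound 1 and compound 3, whose terminal groups hold a six-membered aromatic ring of carbon only, stand at a limit, whereas compound 2 and compound 4, with only six-membered non-aromatic rings, give numbers, and no compound shown goes against this: the limit of > 100000 nM in this assay, at which 2 of the 4 values shown sit.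

Going by these compounds, whether a morpholine or a piperazine at the chain end would separate from compound 2 and compound 4 in this assay remains open. A longer chain between the aromatic oxygen and the terminal group is equally untested here.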